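A few compounds are considered here, and "the series" means these few. Any claim that something is new, unique, unknown or untested is made for them only; others in the source may bear on it.

Compound 1 `CC(C(=O)N1CCN(c2ccccc2C(F)(F)F)CC1)N1C(=O)CCC1=O` was tested in a functional assay on the whole organism (strain Swiss) with Mus musculus as the target, in the maximal electroshock model, with a stated time of 0.5 h, at a dose of 100 mg/kg by the intraperitoneal route (a higher number here means a stronger effect of the compound at the dose given, a lower number a weaker effect), where compound 1 gives 25%. Two companions stand beside it: compound 2 `CCC(C(=O)N1CCN(c2ccccc2)CC1)N1C(=O)CCC1=O` gives 25% in this assay, and compound 3 `CC(C(=O)N1CCN(c2ccc(Cl)cc2)CC1)N1C(=O)CCC1=O` gives 25%. On these numbers compound 1 stands level with compound 2 and with compound 3, the differences lying within the usual scatter, so no ordering among the three can be drawn. The next compound, compound 4 `CC(C(=O)N1CCN(c2ccccc2)CC1)N1C(=O)CCC1=O`, has not yet been measured in this assay. Its change from compound 1 is hydrogen in place of trifluoromethyl on an aromatic carbon. Within the data shown here, no step between measured compounds is available to guide the expectation, and the three measured values sit together, so no step beyond the scatter is expected; the expected step is no change at the digits printed from compound 1 to compound 4 (within the scatter). Compound 4 is therefore estimated at 25%, within a range from 0% to 50%.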

Compound 4, a percentage reported as activity, at one dose (the size of the read-out at that dose, not a potency): 0%
For compound 4 the middle estimate is 25 percentage points above the measured one; low and high end bracket the measured number.
By their numbers in this assay, from the lowest: compound 4; then compounds 1, 2 and 3 (each within the scatter of the next).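

In this assay the result shows that the substituents matter after all: a number 25 percentage points lower from compound 1 to compound 4 (beyond the scatter) with hydrogen in place of trifluoromethyl, and a number 25 percentage points lower from compound 3 to compound 4 (beyond the scatter) with hydrogen in place of chloro on an aromatic carbon. The saturated chain carbon counts too, with a number 25 percentage points lower from compound 2 to compound 4 (beyond the scatter) when hydrogen takes the place of methyl. Nothing available explains these steps. On these data alone, whether a methoxy or fluoro group on the aromatic carbon would keep the effect stays open. So does whether a longer chain on the saturated carbon would.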